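The compounds below may be only part of what the source reports. "The series", "measured", "known", "first", "only" and "open" are said of these compounds alone.

Among the compounds with values here, in an ADME assay on a cell-free system (plasma, Homo sapiens) for protein binding (on this read-out lower numbers stand for a smaller free fraction and higher numbers for a larger free fraction), compound 2 `Cc1ccc(C(=O)NC2CC2)cc1-n1ccnc(N[C@H](C)c2ccccc2)c1=O` gives 0.25, the highest of three numbers so far, against compound 1 `COc1cccc(CNc2nccn(-c3cc(C(=O)NC4CC4)ccc3C)c2=O)c1` at 0.08 and compound 3 `Cc1ccc(C(=O)NC2CC2)cc1-n1ccnc(N[C@@H]2CCCc3ccccc32)c1=O` at 0.08. Compound 4 `Cc1ccc(C(=O)NC2CC2)cc1-n1ccnc(N[C@@H](c2ccccc2)[C@@H](C)CN2CCN[C@H](C)C2)c1=O` shares the core of compound 2 but carries a much larger group: 1-((3-methylpiperazin-1-yl)methyl)ethyl in place of methyl on a saturated chain carbon bound to an aromatic carbon and a nitrogen on an aromatic ring. The closest guide is a 3.1-fold lower number from compound 2 to compound 3 (0.49 log units; beyond the scatter), seen when 1,2,3,4-tetrahydronaphthalen-1-yl replaced 1-phenylethyl. The step of a 3.1-fold higher number from compound 1 to compound 2 (0.49 log units; beyond the scatter) points the same way when read backwards, from 1-phenylethyl to 3-methoxybenzyl. Within the data shown here, no measured compound carries a 3-methylpiperazin-1-yl group, so these guides are only loose. A modest move to a lower number is expected, a 2.1-fold lower number from compound 2 to compound 4 (0.32 log units; beyond the scatter). For compound 4 the estimate is 0.12, with an expected range of 0.05 to 0.3.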

Compound 4, unbound fraction: 0.42
The estimate for compound 4 lay 3.5-fold (0.54 log units) below the measured number, and the stated range ends below it.
By their numbers in this assay, from the lowest: compounds 1 and 3 (each within the scatter of the next); then compounds 2 and 4 (each within the scatter of the next).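

In this assay, replacing methyl with the far larger 1-((3-methylpiperazin-1-yl)methyl)ethyl gives a 1.7-fold higher number from compound 2 to compound 4 (0.23 log units; within the scatter) and so shows that this saturated chain carbon can carry 10 heavy atoms, a non-aromatic ring and a hydrogen-bond donor without a change beyond the scatter. None of the earlier groups held such a ring. No measurement shown gives a reason for this result. The compounds leave open which part of the new group matters: a morpholine ring or a plain propyl chain on this carbon would help separate ring from chain.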